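The source may hold more compounds than are shown below. What is called first, only, known or untested is meant among the compounds shown, and "the series" means these compounds.

Four compounds are compared here for how strongly they hold back a mouse immune cell line, in an ADME assay on RAW264.7 cells (Mus musculus) for cytotoxicity, read by MTT assay, with a stated time of 24 h; a lower number here means a stronger inhibitor, a higher number a weaker inhibitor. Compound 1 `O=CC#Cc1cnc2ccccc2n1` is the simplest of the set; in this assay compound 1 gives 316000 nM. Compound 2 `O=CC#Cc1cnc2cc(Cl)ccc2n1` carries one extra atom on the shared core, the difference being (chloro in place of hydrogen on an aromatic carbon). That single change made a large step, a 69-fold lower number from compound 1 to compound 2 (1.84 log units; beyond the scatter), so that compound 2 gives 4600 nM.

Compound 3 `O=C(OCC#Cc1cnc2ccccc2n1)c1ccccc1` differs from compound 1 by a larger part of the molecule, at the end of the chain away from the core; the difference between the two cores is not broken down here. In this assay compound 3 gives 55600 nM, which lies between the numbers of compound 1 and compound 2.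

Compound 4 `O=C(OCC#Cc1cnc2cc(Cl)ccc2n1)c1ccccc1` has not yet been measured. It stands to compound 3 exactly as compound 2 stands to compound 1: the difference is chloro in place of hydrogen on an aromatic carbon. The entering group and the place of the change are the same in both pairs, so this is the same change. Among the measured compounds shown here, the measured step from compound 1 to compound 2 is the only guide to what it may do on the core of compound 3. Compound 4 is expected to give about 1200 nM, with a likely range from 300 nM to 5000 nM. For the measured compounds named here, this amounts to an expected step of a 46-fold lower number from compound 3 to compound 4 (1.67 log units; beyond the scatter), set somewhat smaller than the measured 69-fold lower number from compound 1 to compound 2 (1.84 log units; beyond the scatter) because the single precedent a 69-fold lower number from compound 1 to compound 2 (1.84 log units; beyond the scatter) may overstate what the change does on a different core.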

Compound 4, half-maximal inhibitory concentration: 82300 nM
For compound 4 the middle estimate is 69-fold (1.84 log units) below the measured one, outside the stated range (above it).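

In this assay, chloro in place of hydrogen on an aromatic carbon gave a 1.5-fold higher number from compound 3 to compound 4 (0.17 log units; within the scatter), so on this second core the change produced no difference that can be told apart from the ordinary spread of repeated measurements. The large step seen on the simpler core therefore did not carry over, and the same change on two closely related cores gave clearly different results: the same change on two cores in this assay, a 69-fold lower number (1.84 log units; beyond the scatter) from compound 1 to compound 2 and a 1.5-fold higher number (0.17 log units; within the scatter) from compound 3 to compound 4, 100-fold (2.01 log units) apart, beyond the scatter of two such steps. Among the compounds shown here, this shows that, in this series, a step measured on one core cannot safely be assumed to hold on another, but with only two matched pairs it does not show which feature of the cores makes the difference, nor how the change would behave on any further core.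

From the compounds shown here alone, whether another group on the same aromatic carbon, such as fluoro or methoxy, would also behave differently on the two cores remains open. Going by these compounds, it is also open how the chloro step would turn out with an amine, a carboxylic acid or a longer chain at the end of the chain away from the core.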